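Working notes: a methoxy step from compound 3

The source may hold more compounds than are shown below. What is called first, only, known or untested is meant among the compounds shown, and "the series" means these compounds.

compound 1 `CCOC(=O)c1c(-c2ccc(OC)cc2)oc2ccc(OCCCCCN3C(=O)C(=O)c4cc(F)ccc43)cc12` gives 512 ug/mL
compound 2 `CCOC(=O)c1c(-c2ccc(OC)cc2)oc2ccc(OCCCCCCN3C(=O)/C(=N\OC)c4ccccc43)cc12` gives 32 ug/mL
compound 3 `CCOC(=O)c1c(-c2ccccc2)oc2ccc(OCCCN3C(=O)/C(=N\OC)c4ccccc43)cc12` gives 64 ug/mL

All three numbers come from an ADME assay on Vero cells (Chlorocebus sabaeus) for cytotoxicity, read by MTT assay, with a stated time of 72 h; a higher number here means that more compound is tolerated, a lower number that less compound is tolerated. Compound 3 (64 ug/mL) lies within the scatter of compound 2 (32 ug/mL) , while compound 1 (512 ug/mL) is higher, beyond the scatter of compound 3.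

The change from compound 3 to compound 4 `CCOC(=O)c1c(-c2ccc(OC)cc2)oc2ccc(OCCCN3C(=O)/C(=N\OC)c4ccccc43)cc12` is methoxy in place of hydrogen on an aromatic carbon. Among the measured compounds shown here, no measured pair isolates this change. Compound 2 (32 ug/mL) already carries the 4-methoxyphenyl group and sits within the scatter of compound 3 (64 ug/mL) , although the two also differ elsewhere. Compound 1 (512 ug/mL) carries the same group but differs from compound 3 in more than one place, so it gives only weak guidance.

In this assay no step beyond the scatter is expected, and the estimate amounts to no change at the digits printed from compound 3 to compound 4 (within the scatter) (an expectation only). For compound 4 the expected value is 64 ug/mL with an estimated range of 24 ug/mL to 200 ug/mL (not yet measured).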

Compound 4, half-maximal cytotoxic concentration: 128 ug/mL
Compound 4: the middle estimate sits 2.0-fold (0.30 log units) below what was measured; measured number inside the range.
By their numbers in this assay, from the lowest: compounds 2, 3 and 4 (each within the scatter of the next, the first and the last beyond it); then compound 1.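

In this assay, among the compounds shown here, this pair gives the first isolated reading of methoxy in place of hydrogen on an aromatic carbon, para to a large group: phenyl to 4-methoxyphenyl gives a 2.0-fold higher number from compound 3 to compound 4 (0.30 log units; within the scatter). The earlier compounds shown here carried the 4-methoxyphenyl group only alongside other differences, whereas here the shared remainder of the structure leaves this change alone, and at this position it stays within the scatter. No evidence on the cause of this step is at hand.

Going by these compounds, whether another group at this position, such as an amine or a carboxylic acid, would give a step beyond the scatter stays open. Also open, on these data alone, is whether the same methoxy change would read alike on a longer chain or alongside the different end group of compound 1.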